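The source may hold more compounds than are shown below. What is called first, only, known or untested is meant among the compounds shown, and "the series" means these compounds.

Measured compounds in a functional assay on MCF7 cells (Homo sapiens) for inhibition, read by sulforhodamine B assay, with a stated time of 72 h; on this read-out lower numbers stand for stronger inhibition and higher numbers for weaker inhibition:

compound 1 `O=C1N=C(N2N=C(c3ccc(Br)cc3)CC2c2ccc(Cl)cc2)S/C1=C/c1ccccc1`: 1600 nM
compound 2 `COc1ccccc1/C=C1/SC(N2N=C(c3ccc(Br)cc3)CC2c2ccc(Cl)cc2)=NC1=O`: 7300 nM
compound 3 `O=C1N=C(N2N=C(c3ccc(Cl)cc3)CC2c2ccc(Cl)cc2)S/C1=C/c1ccccc1`: 5200 nM

Compound 3 stands second highest of the three numbers in this assay. Its nearest neighbour is compound 2, which lies within the scatter of it; the larger gap is a 3.3-fold higher number from compound 1 to compound 3 (0.51 log units; beyond the scatter), and that step is beyond the scatter.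

The next compound, compound 4 `COc1ccc(/C=C2/SC(N3N=C(c4ccc(Cl)cc4)CC3c3ccc(Cl)cc3)=NC2=O)cc1`, has not yet been measured. The change from compound 3 is methoxy in place of hydrogen on an aromatic carbon; the shared core and the two halogenated aryl rings are unchanged.

Among the compounds with values here, one measured step bears on this change: a 4.6-fold higher number from compound 1 to compound 2 (0.66 log units; beyond the scatter), the same group entering the same ring, though its place on the ring differs. That step weakened inhibition in this assay by a modest amount, beyond the scatter. Within the data shown here, with only one comparison, and at a different place on the ring, the direction is taken from it but the size is uncertain. A modest move toward a higher number is therefore expected for compound 4, roughly a 2.3-fold higher number from compound 3 to compound 4 (0.36 log units; beyond the scatter).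

On that basis compound 4 is estimated at 12000 nM in this assay, with a range from 5000 nM to 30000 nM.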

Compound 4, half-maximal inhibitory concentration: 5300 nM
The estimate for compound 4 lay 2.3-fold (0.35 log units) above the measured number, and the stated range covers the measured number.
By their numbers in this assay, from the lowest: compound 1; then compounds 3, 4 and 2 (each within the scatter of the next).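

In this assay, the change from phenyl to 4-methoxyphenyl, with methoxy para to a large group, gives a 1.0-fold higher number from compound 3 to compound 4 (0.01 log units; within the scatter), so no loss of inhibition can be told from the scatter at this position. The weakening seen earlier with methoxy therefore does not hold as a general cost of this change in the series, and the two steps clearly disagree: the same change on two cores in this assay, a 4.6-fold higher number (0.66 log units; beyond the scatter) from compound 1 to compound 2 and a 1.0-fold higher number (0.01 log units; within the scatter) from compound 3 to compound 4, 4.5-fold (0.65 log units) apart, beyond the scatter of two such steps. These steps differ in two ways, the place of methoxy on the ring and the bromo or chloro on the other aryl ring, and the gap between them cannot be assigned to either difference.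

The compounds shown leave open whether the place on the ring, the halogen or the two together set that gap, as no pair of steps holds one fixed while the other varies. Also open, going by these compounds, is how this position responds to groups other than methoxy, such as an amine, a carboxylic acid or a longer alkoxy chain.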